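The source may hold more compounds than are shown below. What is called first, only, known or untested is meant among the compounds shown, and "the series" means these compounds.

Measured so far in a physicochemical assay for solubility, in phosphate buffer, measured as kinetic solubility, at pH 7.4 (on this read-out lower numbers stand for lower solubility and higher numbers for higher solubility), are two compounds
- compound 1 `N#C[C@H]1CCC[C@H]1Nc1ncnc2c(=O)[nH]ccc12` with 104000 nM
- compound 2 `N#C[C@H]1CCC[C@H]1Nc1nc(-c2ccccc2)nc2c(=O)[nH]ccc12` with 11000 nM

Among the compounds with values here, compound 2, at 11000 nM, holds the lower of the two numbers, and compound 1 is its only neighbour. Compound 3 `N#C[C@H]1CCC[C@H]1Nc1nc(-c2cn[nH]c2)nc2c(=O)[nH]ccc12` has not yet been measured. It differs from compound 2 with 1H-pyrazol-4-yl in place of phenyl on an aromatic carbon, between two ring nitrogen atoms, and the count of that change reads 1H-pyrazol-4-yl in place of phenyl on an aromatic carbon as computed from the two structures.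

Within the data shown here, only one measured step bears on this carbon, namely a 9.5-fold lower number from compound 1 to compound 2 (0.98 log units; beyond the scatter), a modest step that brought in phenyl in place of hydrogen. It compares a ring with no ring, whereas compound 3 keeps an aromatic ring there, so it offers only a loose guide. Among the measured compounds shown here, no measured step exchanges one ring for another. A smaller step than that one is therefore expected, upward if it shows at all.

The estimated change is a 1.8-fold higher number from compound 2 to compound 3 (0.26 log units; within the scatter) as an expectation. For compound 3 the expected value is 20000 nM, with an estimated range from 6000 nM to 70000 nM in this assay.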

Compound 3, solubility: 24000 nM
Compound 3: the middle estimate sits 1.2-fold (0.08 log units) below what was measured; the range from low to high includes it.
By their numbers in this assay, from the lowest: compound 2; then compound 3; then compound 1.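

In this assay, the carbon between two ring nitrogen atoms now has a measured exchange of one aromatic ring for another: 1H-pyrazol-4-yl in place of phenyl gives a 2.2-fold higher number from compound 2 to compound 3 (0.34 log units; beyond the scatter). Set against the hydrogen of the parent, the same 1H-pyrazol-4-yl still gives a 4.3-fold lower number from compound 1 to compound 3 (0.64 log units; beyond the scatter), so the number at this carbon depends on which ring is attached and not only on whether a ring is present, and neither of the two rings reaches the number of compound 1. Nothing measured here accounts for the difference between the two rings, and the data do not separate the change in ring size from the change in hetero atoms.

The three compounds leave open whether the step to 1H-pyrazol-4-yl depends on the hydrogen on its ring nitrogen, which a methyl group on that nitrogen would test, and whether a pyridine ring would behave like phenyl or like 1H-pyrazol-4-yl. They also leave open what a non-aromatic group such as morpholine, or a phenyl carrying a carboxylic acid, would do at this carbon.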